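This account rests on a few compounds, and the source may have more. Where it says the series, first, only, none or still open, it means among the compounds named here.

Of the compounds shown here, three have been tested in a functional assay on MCF7 cells (Homo sapiens) for cytotoxicity, read by MTT assay, with a stated time of 72 h (a lower number here means a stronger inhibitor, a higher number a weaker inhibitor), and all three share a thiosemicarbazide-type linker that joins a benzoyl group to a quinazoline-bearing core. Compound 1, `COc1cc2ncnc(NNC(=S)NC(=O)c3ccccc3OC)c2cc1OC`, gives 8800 nM in this assay. Compound 2, `COc1cc2ncnc(NNC(=S)NC(=O)c3ccc(F)cc3)c2cc1OC`, gives 25800 nM in this assay, and it differs from compound 1 in a single place: 4-fluorophenyl in place of 2-methoxyphenyl on a carbonyl carbon. That one exchange produced a 2.9-fold higher number from compound 1 to compound 2 (0.47 log units; beyond the scatter), a weakening that lies beyond the ordinary scatter of repeated measurements.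

Compound 3, `COc1ccccc1C(=O)NC(=S)NNc1ncnc2ccccc12`, gives 8700 nM in this assay. Its number and that of compound 1 lie within the scatter of each other, so neither can be called the stronger of the two. Compound 3 stands on a different core from compound 1, and the difference between the two cores is not broken down here.

Compound 4, `O=C(NC(=S)NNc1ncnc2ccccc12)c1ccc(F)cc1`, has not yet been measured in this assay. It differs from compound 3 in one place: 4-fluorophenyl in place of 2-methoxyphenyl on a carbonyl carbon. This is the same change that turned compound 1 into compound 2, made at the same kind of position, and it appears twice among the four compounds shown. On the core of compound 3 the step is expected to come out at about a 2.9-fold higher number from compound 3 to compound 4 (0.46 log units; beyond the scatter), because on the core of compound 1 the identical exchange gave a 2.9-fold higher number from compound 1 to compound 2 (0.47 log units; beyond the scatter). Compound 4 is therefore expected to give roughly 25000 nM in this assay, with a plausible range from 12000 nM to 55000 nM.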

Compound 4, half-maximal inhibitory concentration: 4590 nM
Beside the measured number, compound 4's estimate is 5.4-fold (0.74 log units) above it; measured number outside the range, below it.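

In this assay, the new pair gives a 1.9-fold lower number from compound 3 to compound 4 (0.28 log units; within the scatter), so on this core 4-fluorophenyl and 2-methoxyphenyl on a carbonyl carbon cannot be told apart, even though the same exchange weakened compound 2 relative to compound 1. The exchange therefore did not carry over as a fixed step from one core to the other, and the effect seen on one core was a poor guide to the other here: the same change on two cores in this assay, a 2.9-fold higher number (0.47 log units; beyond the scatter) from compound 1 to compound 2 and a 1.9-fold lower number (0.28 log units; within the scatter) from compound 3 to compound 4, 5.6-fold (0.74 log units) apart, beyond the scatter of two such steps. Within the data shown here, this does not show that the exchange truly reverses direction on the second core, since that step alone stays within the scatter, and with only one pair on each core it gives no reason for the mismatch and no rule for any further core.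

The compounds shown leave open which part of the exchange matters on each core, the loss of the 2-methoxyphenyl group or the arrival of the 4-fluorophenyl group. A plain phenyl, a 4-methoxyphenyl or a 2-fluorophenyl group on the same carbonyl carbon, on both cores, would help to separate these two parts and show whether the mismatch between the cores persists.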